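Bromo in place of methoxy on compound 3

A few compounds are considered here, and "the series" means these few. Any claim that something is new, unique, unknown or untested is made for them only; others in the source may bear on it.

Three related compounds have been tested in an ADME assay on cells (Hepatocyte, Mus musculus) for cytotoxicity, read by MTT assay, with a stated time of 24 h; on this read-out higher numbers stand for lower toxicity in this test and lower numbers for higher toxicity in this test. Compound 1 (`Cc1ccc(-c2nn(-c3ccccc3)cc2-c2nc3ccccc3[nH]2)cc1`) gives > 300000 nM, and this is a limit of the assay, not a number. Compound 2 (`Cc1ccc(-c2nn(-c3ccccc3)cc2-c2nc3ccccc3n2S(=O)(=O)c2ccccc2)cc1`) gives 189000 nM. Compound 3 (`COc1ccc(S(=O)(=O)n2c(-c3cn(-c4ccccc4)nc3-c3ccc(F)cc3)nc3ccccc32)cc1`) gives 105000 nM, and the numbers of compound 2 and compound 3 lie within the usual scatter of each other.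

Compound 4 (`O=S(=O)(c1ccc(Br)cc1)n1c(-c2cn(-c3ccccc3)nc2-c2ccc(F)cc2)nc2ccccc21`) has not yet been measured. It differs from compound 3 in one place, on an aromatic carbon of a six-membered aromatic ring of carbon only, para to a large group: bromo in place of methoxy on an aromatic carbon. Put simply, 4-methoxyphenyl becomes 4-bromophenyl.

Among the compounds with values here, only one measured step is available, an at least 1.5-fold lower number from compound 1 to compound 2 (0.20 log units; that floor lies within the scatter). That step put phenylsulfonyl in place of hydrogen on an aromatic nitrogen, which is a different change, and its floor lies within the scatter. Within the data shown here, no measured step exchanges bromo for methoxy. The expectation in this assay is therefore no step beyond the scatter, in either direction, starting from compound 3 at 105000 nM. The estimated step is a 1.1-fold lower number from compound 3 to compound 4 (0.02 log units; within the scatter). For compound 4 the expected value is 100000 nM, with an estimated range from 50000 nM to 220000 nM.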

Compound 4, half-maximal cytotoxic concentration: > 300000 nM
Compound 4: a limit, no number (the forecaster's own chance of this, stated with the estimate: 8%); middle value at least 3.0-fold (0.47 log units) from the limit.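

In this assay, within the data shown here, the exchange of (4-methoxyphenyl)sulfonyl for (4-bromophenyl)sulfonyl gives the first step in this set that lies beyond the scatter, an at least 2.8-fold higher number from compound 3 to compound 4 (0.45 log units; beyond the scatter), so a single group on this aromatic carbon, para to a large group, can shift the read-out towards lower toxicity in this test. Compound 4 gives > 300000 nM, which is a limit of the assay and not a number. A sulfonyl group on the aromatic nitrogen therefore does not by itself bring the read-out down to a measured number, and the true size of this step stays unknown because the reading stops at a limit: the limit of > 300000 nM in this assay, at which 2 of the 4 values shown sit.

With only methoxy and bromo compared at this position, the compounds shown cannot separate an effect of having bromo from an effect of losing methoxy, and they do not tell how chloro, an amine or a carboxylic acid would read here. They also leave open whether the same exchange would give a similar step if the other groups on the shared core were different.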